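The compounds below may be only part of what the source reports. "The series", "measured", "known", "first", "only" and "open" are said of these compounds alone.

Compound 1: `Cc1ccc2nc(Cl)c(/C=N/n3cc(-c4cccc5ccccc45)nc3N)cc2c1` — in a functional assay on HCT-116 cells (Homo sapiens) for cytotoxicity, read by MTT assay, with a stated time of 48 h (on this read-out higher numbers stand for weaker inhibition and lower numbers for stronger inhibition), compound 1 gives 5840 nM.
Compound 2: `Cc1ccc2nc(Cl)c(/C=N/n3cc(-c4ccc5ccccc5c4)nc3N)cc2c1` — in this assay compound 2 gives 27400 nM.

Of these two numbers, compound 2 holds the higher one, meaning the weaker inhibition of cell growth. For the measured compounds named here, the single measured step is a 4.7-fold higher number from compound 1 to compound 2 (0.67 log units; beyond the scatter), a modest change in which one naphthyl group is swapped for its isomer on the shared core.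

Compound 3 is `Cc1ccc2nc(Cl)c(/C=N/n3cc(-c4cccs4)nc3N)cc2c1`. Compared with compound 2 the change is thiophen-2-yl in place of naphthalen-2-yl on an aromatic carbon. Going by the values given here, no measured step bears on this exchange: the only step on record, a 4.7-fold higher number from compound 1 to compound 2 (0.67 log units; beyond the scatter), concerns two naphthyl isomers and says nothing about a thiophene. With no guide from the data, the expectation for compound 3 is a step of a 1.8-fold lower number from compound 2 to compound 3 (0.26 log units; within the scatter) in this assay, with a broad range that admits a move either way. The estimated value for compound 3 is 15000 nM, expected to lie between 4000 nM and 60000 nM.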

Compound 3, half-maximal inhibitory concentration: 7710 nM
Beside the measured number, compound 3's estimate is 1.9-fold (0.29 log units) above it; low and high end bracket the measured number.
By their numbers in this assay, from the lowest: compounds 1 and 3 (each within the scatter of the next); then compound 2.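

Until now this position had held only naphthyl groups. Compound 3 shows that a single five-membered aromatic ring containing sulfur can stand there in place of two six-membered aromatic rings of carbon only, and in this assay the exchange gives a 3.6-fold lower number from compound 2 to compound 3 (0.55 log units; beyond the scatter). Set against the other naphthyl isomer, the same group gives a 1.3-fold higher number from compound 1 to compound 3 (0.12 log units; within the scatter), so compound 1 and compound 3 cannot be told apart, and among these three compounds only compound 2 stands clearly apart, which means that the number of ring atoms alone does not set the result. Nothing available explains why these groups differ in this way.

The compounds shown leave open how a plain phenyl ring, a pyridine ring or thiophen-3-yl would compare at this position, and whether a saturated ring such as cyclohexyl would serve as well as the aromatic groups. They also leave open whether the same ranking would hold if the amino group on the five-membered ring were replaced, for example by a methyl group.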